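A few compounds are considered here, and "the series" means these few. Any claim that something is new, unique, unknown or untested is made for them only; others in the source may bear on it.

In an ADME assay on A549 cells (Homo sapiens) for cytotoxicity, read by resazurin assay, with a stated time of 48 h (on this read-out higher numbers stand for lower toxicity in this test and lower numbers for higher toxicity in this test), compound 1 `O=C(Nc1cc(F)cc(C(F)(F)F)c1)c1ccccc1O` gives 16300 nM. Compound 2 `O=C(Nc1cc(F)cc(C(F)(F)F)c1)c1ccc(Cl)cc1O` carries chloro in place of hydrogen on an aromatic carbon and in this assay compound 2 gives 20600 nM; the step is a 1.3-fold higher number from compound 1 to compound 2 (0.10 log units; within the scatter).

Compound 3 `C[C@@H](NC(=O)c1cc(Cl)ccc1O)c1ccccc1` is built on a different core, and the difference between the two cores is not broken down here. In this assay compound 3 gives 84600 nM, the highest of the three numbers.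

Compound 4 `C[C@@H](NC(=O)c1cc(Cl)ccc1O)c1ccc(Cl)cc1` has not been measured yet. It differs from compound 3 by chloro in place of hydrogen on an aromatic carbon. This is the same kind of change as between compound 1 and compound 2, though there the entering chloro also sat meta to a hydroxy group (1 heavy atom), which is not so here.

Beside the earlier step, the expected step is a 1.1-fold higher number from compound 3 to compound 4 (0.05 log units; within the scatter), because the same kind of change gave a 1.3-fold higher number from compound 1 to compound 2 (0.10 log units; within the scatter). Compound 4 is therefore estimated at 95000 nM, with an expected range from 45000 nM to 200000 nM.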

Compound 4, half-maximal cytotoxic concentration: 31100 nM
For compound 4 the middle estimate is 3.1-fold (0.48 log units) above the measured one; the whole stated range lies above it.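

Chloro in place of hydrogen on an aromatic carbon gives a 2.7-fold lower number from compound 3 to compound 4 (0.43 log units; beyond the scatter) in this assay, so on this core the change goes with higher toxicity in this test. The same change does not carry over unchanged from one core to the other: the same change on two cores in this assay, a 1.3-fold higher number (0.10 log units; within the scatter) from compound 1 to compound 2 and a 2.7-fold lower number (0.43 log units; beyond the scatter) from compound 3 to compound 4, 3.4-fold (0.54 log units) apart, beyond the scatter of two such steps

This shows that a step seen on one core cannot simply be transferred to another here, but with one pair per core it does not show whether the core itself or the different place of the entering chloro accounts for the gap. The compounds shown leave open how other groups at the same place on compound 3, such as a methyl group or an amine, would compare with chloro.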